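Estimating Compound 4 After Adding a Trifluoromethyl Group

This account rests on a few compounds, and the source may have more. Where it says the series, first, only, none or still open, it means among the compounds named here.

Compound 1, `CCOC(=O)c1nc(NC(=O)c2ccc(F)cc2)nc2nn(C)cc12`: > 100000 nM
Compound 2, `CCOC(=O)c1nc(NC(=O)c2ccc(C)cc2)nc2nn(C)cc12`: > 100000 nM
Compound 3, `CCOC(=O)c1nc(NC(=O)c2ccccc2)nc2nn(C(C)C)cc12`: 4300 nM

The value of compound 1 in an assay on CHO cells for displacement of a labelled ligand from adenosine receptor A1 (Homo sapiens) (on this read-out higher numbers stand for weaker inhibition and lower numbers for stronger inhibition), is a limit of the assay, not a number. The value of compound 2 in this assay is likewise a limit. Compound 3 therefore stands alone as the only one of the three with a measured number in this assay, 4300 nM. The step from compound 1 to compound 2, a step that the two limits leave unreadable from compound 1 to compound 2, cannot be read because of the limit of > 100000 nM in this assay, at which 2 of the 3 values shown sit.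

Compound 4, `CCOC(=O)c1nc(NC(=O)c2ccc(C(F)(F)F)cc2)nc2nn(C(C)C)cc12`, has not yet been measured. It differs from compound 3 by trifluoromethyl in place of hydrogen on an aromatic carbon; the two share the same core. Among the measured compounds shown here, no measured step bears directly on this change: the single step among the measured compounds is unreadable, and compounds 1 and 2, which each carry a group at the same place on the ring as the trifluoromethyl of compound 4, differ from compound 3 in a second place as well, so what their values show cannot be separated from that second difference.

Relative to compound 3, compound 4 is expected to be somewhat weaker, by an estimated step of a 3.5-fold higher number from compound 3 to compound 4 (0.54 log units; beyond the scatter), with low confidence. The estimate for compound 4 in this assay is 15000 nM. For compound 4 the expected range runs from 3000 nM to 80000 nM.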

Compound 4, inhibition constant: > 100000 nM
Compound 4: a limit, no number; the forecaster's own chance of this, stated with the estimate: 30%; middle value at least 6.6-fold (0.82 log units) from the limit.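

In this assay compound 4 gives > 100000 nM, which is a limit of the assay and not a number. Among the compounds shown here, the step from compound 1 to compound 2 cannot be read, but with the rest of the molecule unchanged, the change from phenyl to 4-(trifluoromethyl)phenyl gives the first readable step at this place on the ring, para to a large group: an at least 23-fold higher number from compound 3 to compound 4 (1.36 log units; beyond the scatter). This shows that adding trifluoromethyl here clearly weakens the result, yet it fixes only the smallest possible size of the step, because one of its two ends is a limit: the limit of > 100000 nM in this assay, at which 3 of the 4 values shown sit.

Compounds 1 and 2 also carry a group at this place, but they differ from compound 3 in a second place as well, so the compounds shown cannot tell whether trifluoromethyl alone has this effect or whether any group here would do the same. As far as these compounds go, how a smaller or differently built group at this place, such as an amine, a methoxy group or a carboxylic acid, would read in this assay also remains open.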